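Replacing a Pyrrolidine Side Chain with a Hydroxyl

The source may report more compounds than this note shows. Statements on the series, on what has been measured and on what is new or still open speak of the compounds shown alone.

Of the compounds shown here, three sharing one core have been tested in a functional assay on LNCaP cells (Homo sapiens) for antiproliferative activity; a lower number here means a stronger inhibitor, a higher number a weaker inhibitor. Compound 1 `Cn1ncc(Cl)c1-c1cc(C(=O)N[C@@H]2CN[C@H](CCn3cncn3)C[C@H]2c2ccc(Cl)c(Cl)c2)oc1Cl` gives 60 nM. Compound 2 `CC(=O)NCC[C@@H]1C[C@@H](c2ccc(F)c(F)c2)[C@H](NC(=O)c2cc(-c3c(Cl)cnn3C)c(Cl)o2)CN1`, which differs from the others in both its side chain and its aryl group, gives 130 nM. Compound 3 `Cn1ncc(Cl)c1-c1cc(C(=O)N[C@@H]2CN[C@H](CCN3CCCC3)C[C@H]2c2ccc(Cl)c(Cl)c2)oc1Cl` gives 1920 nM, the highest number of the three and therefore the weakest inhibitor among them.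

Compound 4 `Cn1ncc(Cl)c1-c1cc(C(=O)N[C@@H]2CN[C@H](CCO)C[C@H]2c2ccc(Cl)c(Cl)c2)oc1Cl` has not yet been measured. It differs from compound 3 in one place: hydroxy in place of pyrrolidin-1-yl on a saturated chain carbon, two bonds along the chain from a saturated ring carbon.

Among the measured compounds shown here, one measured step bears on this change. The same side-chain position was altered in the step of a 32-fold higher number from compound 1 to compound 3 (1.51 log units; beyond the scatter), so exchanging the pyrrolidin-1-yl group for a different small substituent has already shifted the number strongly at this site. Because compound 1 gives 60 nM and compound 2 gives 130 nM with other small groups on that chain, a move back toward those values is expected, as a 7.7-fold lower number from compound 3 to compound 4 (0.89 log units; beyond the scatter).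

Compound 4 is therefore estimated at 250 nM, with a likely range from 70 nM to 900 nM.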

Compound 4, half-maximal inhibitory concentration: 160 nM
Beside the measured number, compound 4's estimate is 1.6-fold (0.19 log units) above it, within the range that was stated.
By their numbers in this assay, from the lowest: compound 1; then compounds 2 and 4 (each within the scatter of the next); then compound 3.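

On this 2-substituted ethyl chain, a lone hydroxy takes the place of the whole pyrrolidin-1-yl ring with a large drop in the number in this assay (a 12-fold lower number from compound 3 to compound 4 (1.08 log units; beyond the scatter)), so no ring at this position is needed for a number far lower than that of compound 3. The triazolyl group still keeps an edge over hydroxy, though the gap is modest (a 2.7-fold higher number from compound 1 to compound 4 (0.43 log units; beyond the scatter)), which makes pyrrolidin-1-yl the clear outlier among the three groups compared on this core. Nothing available explains why these groups differ.

The compounds shown leave open whether the high number follows other amines on this chain, such as dimethylamino or piperidin-1-yl, or belongs to pyrrolidin-1-yl alone. As far as these compounds go, how a methoxy group, a carboxylic acid or a longer chain ending in hydroxy would compare also remains open.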